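From methoxy to hydroxy on a potent growth inhibitor

The source may report more compounds than this note shows. Statements on the series, on what has been measured and on what is new or still open speak of the compounds shown alone.

In a functional assay on MCF7 cells (Homo sapiens) for antiproliferative activity (a higher number here means a weaker inhibitor of growth, a lower number a stronger inhibitor of growth), the measured compounds stand as follows:
compound 1 `CC/C=C\[C@H](C)[C@H](OC(N)=O)[C@@H](C)[C@H](O)[C@@H](C)C/C(C)=C\[C@H](C)[C@@H](O)[C@@H](C)/C=C\[C@@H](O)C[C@H](O)[C@H](C)C[C@H](C)C(=O)OC` gives 1000 nM
compound 2 `CC/C=C\[C@H](C)[C@H](OC(N)=O)[C@@H](C)[C@H](O)[C@@H](C)C/C(C)=C\[C@H](C)[C@@H](O)[C@@H](C)/C=C\[C@@H](O)C[C@@H]1OC(=O)NC[C@H]1C` gives 110 nM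
compound 3 `CC/C=C\[C@H](C)[C@H](OC(N)=O)[C@@H](C)[C@H](O)[C@@H](C)C/C(C)=C\[C@H](C)[C@@H](O)[C@@H](C)/C=C\[C@@H](O)C[C@@H]1OC(=O)[C@H](C)[C@@H](OC)[C@H]1C` gives 3.8 nM

Compound 3 holds the lowest number of the three, and its steps to both others lie beyond the scatter. Compound 4 `CC/C=C\[C@H](C)[C@H](OC(N)=O)[C@@H](C)[C@H](O)[C@@H](C)C/C(C)=C\[C@H](C)[C@@H](O)[C@@H](C)/C=C\[C@@H](O)C[C@@H]1OC(=O)[C@H](C)[C@@H](O)[C@H]1C` differs from compound 3 by hydrogen in place of methyl on an oxygen on a saturated carbon on an oxygen on a saturated carbon. The same difference reads methoxy to hydroxy.

Each measured step swaps a whole group, so none of them measures this small change directly. Of these, a 9.1-fold lower number from compound 1 to compound 2 (0.96 log units; beyond the scatter) counts as modest, whereas a 260-fold lower number from compound 1 to compound 3 (2.42 log units; beyond the scatter) and a 29-fold lower number from compound 2 to compound 3 (1.46 log units; beyond the scatter) count as large. They show that the number can move a long way when that whole group is exchanged. Compound 4 keeps all of the group in compound 3 except one methyl, so a much smaller step is expected here. Compound 3 already has the lowest number, and so the expected direction is towards a somewhat higher number in this assay rather than a lower one. The expected change is a 2.4-fold higher number from compound 3 to compound 4 (0.37 log units; beyond the scatter) and it remains uncertain. Compound 4 is estimated at 9 nM (expected range 2.5 nM to 35 nM).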

Compound 4, concentration for 50% growth inhibition: 6.2 nM
Compound 4: middle estimate off by 1.5-fold (0.16 log units), on the high side, within the range that was stated.
By their numbers in this assay, from the lowest: compounds 3 and 4 (each within the scatter of the next); then compound 2; then compound 1.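

Removing the methyl from the oxygen on a saturated carbon gives a 1.6-fold higher number from compound 3 to compound 4 (0.21 log units; within the scatter) in this assay, so in this assay methoxy and hydroxy cannot be told apart at this position. The earlier compounds shown here could not show this, since each of their steps exchanged a whole group. The group carrying the hydroxy also keeps the large gains seen for the group in compound 3, with an 18-fold lower number from compound 2 to compound 4 (1.25 log units; beyond the scatter) and a 160-fold lower number from compound 1 to compound 4 (2.21 log units; beyond the scatter), which means that this methyl is not needed for those gains. Nothing available explains why the change leaves the number within the scatter.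

The compounds shown cover only hydrogen and methyl on this oxygen, so it stays open whether a longer chain such as butyl there, or an amine in place of the hydroxy, would keep the number as low as in compound 3 and compound 4. From the compounds shown here alone, with a single assay on one cell type, it also stays open whether methoxy and hydroxy would remain this close in any other measurement.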